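The compounds below may be only part of what the source reports. "The series", "measured", "known", "first", "only" and "open" are said of these compounds alone.

Measured so far in an ADME assay on Huh-7 cells (Homo sapiens) for cytotoxicity; a lower number here means that less compound is tolerated, a higher number that more compound is tolerated:

- compound 1 `CN1CCN(CCCNCc2cn(-c3ccc([N+](=O)[O-])cc3)nc2-c2ccc(OC(F)(F)F)cc2)CC1`: 1600 nM
- compound 2 `CN1CCN(CCNCc2cn(-c3ccc(F)cc3F)nc2Cc2ccccc2)CC1`: > 20000 nM
- compound 3 `CCCN1CCC(CNCc2cn(-c3ccc(C(F)(F)F)cc3)nc2-c2ccc(C(F)(F)F)cc2)CC1`: 1200 nM

Compound 2 stands at a limit of this assay, not at a number: its value of > 20000 nM is the limit, and (the limit of > 20000 nM in this assay, at which 1 of the 3 values shown sits). Compound 2 is the only one of the three that reaches it. Compound 1 and compound 3 each give a number, and the two numbers sit within the usual scatter of each other.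

Compound 4 `CN1CCN(CCNCc2cn(-c3ccc(F)cc3F)nc2-c2ccccc2Cl)CC1` is not yet measured. The change from compound 2 to compound 4 is 2-chlorophenyl in place of benzyl on an aromatic carbon. Among the measured compounds shown here, no step between two measured compounds is known that matches this change, so the expectation rests on the three values alone. Compound 1 and compound 3 both carry a substituted phenyl group at the place where compound 2 carries benzyl, and both give numbers well under the limit. A step from compound 2 to compound 4 in this assay is therefore expected to go downward, beyond the scatter, toward the region of compound 1 and compound 3; the expected step is an at least 4.0-fold lower number from compound 2 to compound 4 (0.60 log units; beyond the scatter). Compound 4 is estimated at 5000 nM in this assay, with a range from 1500 nM to 20000 nM.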

Compound 4, half-maximal cytotoxic concentration: > 20000 nM
Compound 4 ended at the assay's limit; the forecaster's own chance of this, stated with the estimate: 30%; middle value at least 4.0-fold (0.60 log units) from the limit.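

Compound 2 and compound 4 both end at a limit rather than a number, so no step between them can be read in this assay: the limit of > 20000 nM in this assay, at which 2 of the 4 values shown sit.

The compounds shown leave open whether 2-chlorophenyl in place of benzyl on an aromatic carbon changes the result in this assay at all, and if so, by how much.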